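Three Limits and a Benzoylmethyl Substitution

This account rests on a few compounds, and the source may have more. Where it says the series, first, only, none or still open, it means among the compounds named here.

compound 1 `C#CCSc1nnc(C)n1N1C(=O)c2ccccc2C1=O` — in a functional assay on A549 cells (Homo sapiens) for cytotoxicity, read by MTT assay, with a stated time of 48 h (on this read-out higher numbers stand for weaker inhibition and lower numbers for stronger inhibition), a limit only: > 200000 nM
compound 2 `CCOC(=O)CSc1nnc(CC)n1N1C(=O)c2ccccc2C1=O` — in this assay a limit only: > 200000 nM
compound 3 `C#CCSc1nnc(-c2cc(OC)c(OC)c(OC)c2)n1N1C(=O)c2ccccc2C1=O` — in this assay a limit only: > 200000 nM

Compound 3 therefore stands nowhere distinct: all three measured compounds sit at the same limit, (the limit of > 200000 nM in this assay, at which 3 of the 3 values shown sit), and no number separates them. Compound 4 `COc1cc(-c2nnc(SCC(=O)c3ccccc3)n2N2C(=O)c3ccccc3C2=O)cc(OC)c1OC` differs from compound 3 by benzoyl in place of ethynyl on a saturated chain carbon bound to a sulfur. Among the measured compounds shown here, no pair of measured compounds differing in one place exists, so no step size is on record. The step of a number no higher from compound 3 to compound 4 (the limit leaves the size open) is expected to be none beyond the scatter, with the result most likely again a limit. Compound 4 is thus estimated at 200000 nM in this assay, within 50000 nM to 400000 nM.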

Compound 4, half-maximal inhibitory concentration: > 200000 nM
Compound 4: a limit, no number; the forecaster's own chance of this, stated with the estimate: 70%; the middle value lies on the limit itself.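

In this assay, among the compounds shown here, compound 3 and compound 4 both stand only as limits, so no step between them can be read. The compounds shown leave open whether propargyl to benzoylmethyl changes the read-out at all.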